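Triazole series on colon cancer cells: methyl for methoxy

The source may report more compounds than this note shows. Statements on the series, on what has been measured and on what is new or still open speak of the compounds shown alone.

Compound 1 `C=C1C[C@]23C[C@@]1(O)CC[C@@H]2c1cccc(C)c1[C@@H]3Cn1cc(-c2ccc(OC)cc2)nn1` and compound 3 `C=C1C[C@]23C[C@@]1(O)CC[C@@H]2c1cccc(C)c1[C@@H]3Cn1cc(-c2ccc(C)cc2)nn1` share one core and differ only in the group on the pendant aromatic ring, (methyl in place of methoxy on an aromatic carbon). Compound 2 `C=C1C[C@]23C[C@@]1(O)CC[C@H]2c1ccc(O)c(C)c1[C@@H]3Cn1cc(-c2ccc(OC)cc2)nn1` carries a second core; the difference between the two cores is not broken down here. Compound 4 `C=C1C[C@]23C[C@@]1(O)CC[C@H]2c1ccc(O)c(C)c1[C@@H]3Cn1cc(-c2ccc(C)cc2)nn1` is not yet measured and stands to compound 2 as compound 3 stands to compound 1: methyl in place of methoxy on an aromatic carbon. The two places are described in the same words, so this is the same change on a different core.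

In a functional assay on SW480 cells (Homo sapiens) for cytotoxicity, read by MTT assay, with a stated time of 4 days (on this read-out higher numbers stand for weaker inhibition and lower numbers for stronger inhibition), compound 1 gives > 20000 nM, which is a limit of the assay and not a number. In this assay compound 3 gives > 20000 nM, again a limit. In this assay compound 2 gives > 20000 nM, also a limit. The step that the two limits leave unreadable from compound 1 to compound 3 therefore cannot be read, because of the limit of > 20000 nM in this assay, at which 3 of the 3 values shown sit.

For compound 4 nothing in the shown data points to a value that would leave the limit: the change on compound 1 did not do so, and compound 2 already sits at the limit. The step from compound 2 to compound 4 is expected to be about a step that the limit leaves unreadable from compound 2 to compound 4, resting on compound 1 at > 20000 nM and compound 3 at > 20000 nM. Compound 4 is expected to give roughly 30000 nM in this assay, most likely reported as a limit again, within 15000 nM to 100000 nM.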

Compound 4, half-maximal inhibitory concentration: > 20000 nM
Compound 4 ended at the assay's limit; the forecaster's own chance of this, stated with the estimate: 85%; the middle value is on the limit's open side.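

In this assay compound 4 gives > 20000 nM, a limit of the assay and not a number. No new step can be read between compound 2 and compound 4, because both sit at that limit: the limit of > 20000 nM in this assay, at which 4 of the 4 values shown sit.

The compounds shown leave open whether methyl in place of methoxy on an aromatic carbon makes any difference on either core, and how the two cores compare.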